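This account rests on a few compounds, and the source may have more. Where it says the series, first, only, none or still open, it means among the compounds named here.

Measured so far in a functional assay on MDA-MB-231 cells (Homo sapiens) for antiproliferative activity, read by MTT assay, with a stated time of 72 h; a lower number here means a stronger inhibitor, a higher number a weaker inhibitor:

compound 1 `CCOC(=O)c1ccc(NC(=O)CCc2cccc3c2B(O)OC3)cc1`: > 100000 nM.
compound 2 `COc1ccccc1NC(=O)CCc1cccc2c1B(O)OC2`: 930 nM.
compound 3 `O=C(CCc1cccc2c1B(O)OC2)Nc1cccc(-c2ccccc2)c1`: 220 nM.

For compound 1 the entry is a limit of this assay, not a number (the limit of > 100000 nM in this assay, at which 1 of the 3 values shown sits). Among the two real numbers compound 3 holds the lower one; the gap from compound 3 to compound 2 lies beyond the scatter. Going by the values given here, no pair of measured compounds differs in a single place, so no step has been measured directly.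

Compound 4 `CC(=O)c1cccc(-c2cccc(NC(=O)CCc3cccc4c3B(O)OC4)c2)c1` has not yet been run in this assay. It differs from compound 3 by acetyl in place of hydrogen on an aromatic carbon.

With no measured step of this kind in the series, the change from compound 3 to compound 4 is expected to shift the number by a 1.1-fold lower number from compound 3 to compound 4 (0.04 log units; within the scatter), which is within the scatter. Compound 4 is therefore estimated at 200 nM, with a range from 70 nM to 600 nM.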

Compound 4, half-maximal inhibitory concentration: 52 nM
Beside the measured number, compound 4's estimate is 3.8-fold (0.59 log units) above it, outside the stated range (below it).
By their numbers in this assay, from the lowest: compound 4; then compound 3; then compound 2. At a limit, above all of these: compound 1.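

In this assay, going by these compounds alone, acetyl in place of hydrogen on an aromatic carbon, meta to a large group, gives a 4.2-fold lower number from compound 3 to compound 4 (0.63 log units; beyond the scatter) and is the only single-place step read so far. The position therefore responds to substitution, and the change from phenyl to 3-acetylphenyl moves the number lower. No measured property bears on this step. From the compounds shown here alone, whether the lower number is specific to acetyl, or would also follow from an amine or a carboxylic acid at this place, stays open. Also open, going by these compounds, is whether other places on that ring respond in the same way.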